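From Ethyl to 4-Methoxyphenyl on the Amide Nitrogen

The source may report more compounds than this note shows. Statements on the series, on what has been measured and on what is new or still open speak of the compounds shown alone.

compound 1 `COc1ccc(-n2nc(C(N)=O)nc2-c2cc(OC)c(OC)c(OC)c2)cc1`: 92%
compound 2 `CNC(=O)c1nc(-c2cc(OC)c(OC)c(OC)c2)n(-c2ccc(OC)cc2)n1`: 95%
compound 3 `CCNC(=O)c1nc(-c2cc(OC)c(OC)c(OC)c2)n(-c2ccc(OC)cc2)n1`: 88%

The three measured compounds share one core and differ only in the substituent on the amide-type nitrogen. In a functional assay on the whole organism for inhibition, with Rattus norvegicus as the target, read by paw edema, with stated times of 30 min and 3 h, at a dose of 0.28 mmol/kg by the oral route (a lower number here means less inhibition, a higher number more inhibition at the dose given (going by the name of the read-out)), compound 3 gives 88%, the low end of a narrow band: a number 4 percentage points lower from compound 1 to compound 3 (within the scatter) and a number 7 percentage points lower from compound 2 to compound 3 (within the scatter), both within the scatter, as is a number 3 percentage points higher from compound 1 to compound 2 (within the scatter). Compound 4 `COc1ccc(NC(=O)c2nc(-c3cc(OC)c(OC)c(OC)c3)n(-c3ccc(OC)cc3)n2)cc1` carries the change (4-methoxyphenyl in place of ethyl on an amide-type nitrogen). Every step measured so far touches this same nitrogen, yet all swap only hydrogen, methyl and ethyl and none moves beyond the scatter; the entering 4-methoxyphenyl is a larger group, so the comparison is looser. The expectation is still no step beyond the scatter, a number 4 percentage points lower from compound 3 to compound 4 (within the scatter), with a wider range than the measured spread. Compound 4 is therefore estimated at 84%, between 60% and 97%.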

Compound 4, a percentage reported as inhibition, in the whole organism at one dose (the size of the read-out at that dose, not a potency): 86%
Compound 4: the middle estimate sits 2 percentage points below what was measured; low and high end bracket the measured number.
By their numbers in this assay, from the lowest: compounds 4, 3, 1 and 2 (each within the scatter of the next).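

In this assay, within the data shown here, the amide-type nitrogen carries an aromatic ring for the first time, and 4-methoxyphenyl stays level with all three smaller substituents: a number 2 percentage points lower from compound 3 to compound 4 (within the scatter) and a number 9 percentage points lower from compound 2 to compound 4 (within the scatter) and a number 6 percentage points lower from compound 1 to compound 4 (within the scatter). The position therefore accepts this larger group, with its added hydrogen-bond acceptor, without any step beyond the scatter at this one dose. No available evidence explains this result.

The compounds shown leave open whether a longer chain, a carboxylic acid or an amine on this nitrogen would stay within the same band. They also do not separate the four substituents from one another at this dose.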